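The source may report more compounds than this note shows. Statements on the series, on what has been measured and on what is new or still open speak of the compounds shown alone.

Compound 1 `CN1C(=S)[C@@H](NC(=O)c2nc(Cc3ccccc3)n(CCCF)n2)COc2ccccc21` and compound 2 `CN1C(=S)[C@@H](NC(=O)c2nc(Cc3ccccc3)n(CCCCC#N)n2)COc2ccccc21` share one core and differ only in the chain attached to an aromatic nitrogen. In a functional assay on HT-29 cells (Homo sapiens) for inhibition, read by luminescence and CellTiter-Glo, with a stated time of 24 h (on this read-out lower numbers stand for an effect already at smaller amounts and higher numbers for an effect only at larger amounts of compound), compound 1 gives 4760 nM, and in the same assay compound 2 gives 2680 nM. Among the compounds with values here, compound 2 stands at the lowest of the two numbers so far, yet the step of a 1.8-fold lower number from compound 1 to compound 2 (0.25 log units; within the scatter) lies within the scatter, so the two compounds cannot really be separated. Compound 3 `CN1C(=S)[C@@H](NC(=O)c2nc(Cc3ccccc3)n(C3CCNCC3)n2)COc2ccccc21` has not yet been measured; it differs from compound 2 by piperidin-4-yl in place of 4-cyanobutyl on an aromatic nitrogen. Within the data shown here, the single measured step, a 1.8-fold lower number from compound 1 to compound 2 (0.25 log units; within the scatter), concerns a change at the end of the chain and stayed within the scatter. Among the measured compounds shown here, no measured step exchanges a chain for a ring bearing a hydrogen-bond donor, so there is no ground for expecting a shift in either direction. Compound 3 is therefore estimated at 3000 nM, with a range from 700 nM to 13000 nM. This estimate means an expected step of a 1.1-fold higher number from compound 2 to compound 3 (0.05 log units; within the scatter), which is no step beyond the scatter.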

Compound 3, half-maximal effective concentration: 1000 nM
Beside the measured number, compound 3's estimate is 3.0-fold (0.48 log units) above it; the measured number falls inside the stated range.
By their numbers in this assay, from the lowest: compound 3; then compounds 2 and 1 (each within the scatter of the next).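

Exchanging an open chain for a ring on this aromatic nitrogen moves the number in this assay beyond the scatter: the change gives a 2.7-fold lower number from compound 2 to compound 3 (0.43 log units; beyond the scatter) and, measured against the fluorinated chain, a 4.8-fold lower number from compound 1 to compound 3 (0.68 log units; beyond the scatter), both modest in size. Within the data shown here, the two chains alone could not be separated, so this is the first sign that the position responds to what sits on it, even though piperidin-4-yl and 4-cyanobutyl have the same count of heavy atoms and differ in the ring and the hydrogen-bond donor that piperidin-4-yl brings. No outside measurement accounts for the shift.

As far as these compounds go, whether the ring or its nitrogen carries the step stays open. A cyclohexyl ring would keep the ring without that nitrogen, and a 4-aminobutyl chain would keep an amine without the ring, but neither stands among the compounds shown.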